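From a carboxylic acid to a methoxy group on the aryl ether

The source may hold more compounds than are shown below. What is called first, only, known or untested is meant among the compounds shown, and "the series" means these compounds.

Measured compounds:
compound 1 `Cc1ccc(OCCCCOc2ccc(C(=O)CC(C)(C)C)c(O)c2C)cc1C(=O)O`: 309 nM
compound 2 `Cc1ccc(C(=O)O)cc1OCCCCOc1ccc(C(=O)CC(C)(C)C)c(O)c1C`: 892 nM
compound 3 `Cc1ccc(OC[C@H](C)COc2ccc(C(=O)CC(C)(C)C)c(O)c2C)cc1C(=O)O`: limit only

In an assay for positive allosteric modulation of metabotropic glutamate receptor 3 (Rattus norvegicus) (a lower number here means that less compound is needed, a higher number that more compound is needed for the effect), compound 1 gives 309 nM and compound 2 gives 892 nM; the step is a 2.9-fold higher number from compound 1 to compound 2 (0.46 log units; beyond the scatter). For compound 3 the assay reports a limit rather than a number, > 10000 nM, (the limit of > 10000 nM in this assay, at which 1 of the 3 values shown sits).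

Compound 4 `COc1cccc(OC[C@H](C)COc2ccc(C(=O)CC(C)(C)C)c(O)c2C)c1` differs from compound 3 in one place: 3-methoxyphenyl in place of 3-carboxy-4-methylphenyl on an oxygen on a saturated carbon. Within the data shown here, the single measured step moves the carboxylic acid around the ring rather than removing it, so no measured step speaks directly to this change. With compound 3 already at the limit, compound 4 is expected to stay there or near it, a step that the limit leaves unreadable from compound 3 to compound 4. Compound 4 is therefore estimated at 20000 nM, within a range of 5000 nM to 100000 nM.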

Compound 4, half-maximal effective concentration: "not active" (no number reported)
For compound 4 the study gives words and no number, and the estimate cannot be compared.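

Among these compounds, compound 3 carries only a limit, > 10000 nM, and compound 4 is reported in words alone, so no step between compound 3 and compound 4 can be read. As far as these compounds go, whether 3-methoxyphenyl and 3-carboxy-4-methylphenyl differ at all in this place remains open.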